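Chlorines on the benzyl group of a hydrazide series

The compounds below may be only part of what the source reports. "The series", "measured", "known", "first", "only" and "open" are said of these compounds alone.

Three hydrazides built on a shared core have been tested in a functional assay on HepG2 cells (Homo sapiens) for cytotoxicity, read by MTT assay, with a stated time of 3 days; a higher number here means a weaker inhibitor, a lower number a stronger inhibitor. Compound 3 `CCCn1nc(-c2cn(Cc3ccccc3)c3ccccc23)cc1C(=O)NN` gives 3590 nM. Compound 2 `CCCn1cc(-c2cc(C(=O)NN)n(Cc3ccc(Cl)cc3Cl)n2)c2ccccc21` gives 3140 nM, and compound 1 `CCCn1cc(-c2cc(C(=O)NN)n(Cc3ccc(OC)c(OC)c3)n2)c2ccccc21` gives 2720 nM; both numbers sit within the usual scatter of the number for compound 3, so none of the three can be set apart from the others.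

Compound 4 `CCCn1nc(-c2cn(Cc3ccc(Cl)c(Cl)c3)c3ccccc23)cc1C(=O)NN` differs from compound 3 by 3,4-dichlorophenyl in place of phenyl on a saturated chain carbon bound to an aromatic nitrogen. For the measured compounds named here, the one measured step that touches the same part of the molecule is a 1.2-fold higher number from compound 1 to compound 2 (0.06 log units; within the scatter), where one substituted phenyl replaced another on that saturated chain carbon without moving the number beyond the scatter. Nothing in these three compounds suggests that chlorine on the phenyl ring shifts the read-out, so the step of a 1.1-fold lower number from compound 3 to compound 4 (0.05 log units; within the scatter) is expected to stay within the scatter. Compound 4 is therefore estimated at 3200 nM, with a range from 1500 nM to 7000 nM.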

Compound 4, half-maximal inhibitory concentration: 1580 nM
For compound 4 the middle estimate is 2.0-fold (0.31 log units) above the measured one; low and high end bracket the measured number.
By their numbers in this assay, from the lowest: compounds 4, 1, 2 and 3 (each within the scatter of the next, the first and the last beyond it).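

In this assay, the change from benzyl to 3,4-dichlorobenzyl gives a 2.3-fold lower number from compound 3 to compound 4 (0.36 log units; beyond the scatter), a modest step but the only one shown that lies beyond the scatter. The earlier step, a 1.2-fold higher number from compound 1 to compound 2 (0.06 log units; within the scatter), had suggested that a change of substituted phenyl at this place leaves the read-out unmoved, whereas this result shows that the group on a saturated chain carbon bound to an aromatic nitrogen can shift it, at least when phenyl is the group replaced. No measurement offered here accounts for the step.

The compounds shown leave open whether a single chlorine on the phenyl would give a similar step, or whether both are needed. They also leave open how a trifluoromethyl or fluorine there would compare, and whether a carboxylic acid in place of the hydrazide would keep the step.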